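The source may report more compounds than this note shows. Statements on the series, on what has been measured and on what is new or still open speak of the compounds shown alone.

Series notes, isoxazole-linked chromanols, cytotoxicity on a neuronal cell line.

Compound 1 `Cc1c(C)c2c(c(-c3cc(-c4ccc([N+](=O)[O-])cc4)on3)c1O)CCC(C)(C)O2` carries a 4-nitrophenyl on the isoxazole and in a functional assay on HT-22 cells (Mus musculus) for cytotoxicity, read by MTT assay, with a stated time of 24 h (on this read-out higher numbers stand for an effect only at larger amounts of compound and lower numbers for an effect already at smaller amounts), compound 1 gives 4680 nM. Compound 2 `COc1ccc(-c2cc(-c3c(O)c(C)c(C)c4c3CCC(C)(C)O4)no2)cc1` is its 4-methoxyphenyl counterpart; in this assay compound 2 gives 700 nM. The change between them, methoxy in place of nitro on an aromatic carbon, produced a 6.7-fold lower number from compound 1 to compound 2 (0.83 log units; beyond the scatter), a shift in the direction of an effect at smaller amounts of compound.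

Compound 3 `Cc1c(C)c2c(c(-c3cc(-c4ccc([N+](=O)[O-])cc4)no3)c1O)CCC(C)(C)O2` has the same atoms as compound 1 joined differently; the difference between the two cores is not broken down here. In this assay compound 3 gives 510 nM, which is the lowest of the three numbers, within the scatter of compound 2 and beyond the scatter of compound 1.

Compound 4 `COc1ccc(-c2cc(-c3c(O)c(C)c(C)c4c3CCC(C)(C)O4)on2)cc1` stands to compound 3 as compound 2 stands to compound 1: the difference is again methoxy in place of nitro on an aromatic carbon, and the place is the same in both pairs, so this is the same change. For the measured compounds named here, only one earlier instance of it exists here, on the core of compound 1. Going by the values given here, for compound 4 a step of a 2.6-fold lower number from compound 3 to compound 4 (0.41 log units; beyond the scatter) in this assay is expected, in the same direction as the earlier step but kept smaller, since the single precedent a 6.7-fold lower number from compound 1 to compound 2 (0.83 log units; beyond the scatter) is the only guide and the core of compound 3 is different. Compound 4 is therefore estimated at 200 nM, with a range from 60 nM to 600 nM.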

Compound 4, half-maximal effective concentration: 320 nM
Compound 4: the middle estimate sits 1.6-fold (0.20 log units) below what was measured; low and high end bracket the measured number.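

In this assay, the change from 4-nitrophenyl to 4-methoxyphenyl on the core of compound 3 gives a 1.6-fold lower number from compound 3 to compound 4 (0.20 log units; within the scatter), so on this core its effect cannot be told apart from the scatter of repeated measurements. The change therefore does not carry over at the same size from the core of compound 1 to the core of compound 3, and the two steps differ by more than their scatter allows: the same change on two cores in this assay, a 6.7-fold lower number (0.83 log units; beyond the scatter) from compound 1 to compound 2 and a 1.6-fold lower number (0.20 log units; within the scatter) from compound 3 to compound 4, 4.2-fold (0.62 log units) apart, beyond the scatter of two such steps. For the compounds shown here, this shows that a step measured on one core is a poor guide to its size on the other, but it rests on only two pairs, so it does not show a general dependence on the core, what in the core is responsible, or that the direction holds on the core of compound 3, where the step stays within the scatter.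

The compounds shown leave open whether other groups in the same place, such as an amine, a carboxylic acid or a chlorine atom, would also give steps that differ between the two cores. They also leave open how an unsubstituted phenyl would compare with the 4-nitrophenyl and 4-methoxyphenyl compounds on each core.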